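Moving from compound 3 to compound 4 in the growth assay

The source may hold more compounds than are shown below. What is called first, only, known or untested is meant among the compounds shown, and "the series" means these compounds.

Compound 1 `COc1ccc(-c2[nH]c3ccccc3c2/C=C(\C#N)S(=O)(=O)c2ccccc2)cc1` gives 1100 nM in a functional assay on A498 cells (Homo sapiens) for inhibition, read by sulforhodamine B assay, with a stated time of 48 h (a higher number here means a weaker inhibitor of growth, a lower number a stronger inhibitor of growth), and compound 2 `CCOC(=O)C(=Cc1c(-c2ccccc2)[nH]c2ccccc12)C(=O)OCC` gives 16900 nM in this assay. As far as these compounds go, compound 3 `COc1ccc(-c2[nH]c3ccc(OC)cc3c2/C=C(\C#N)S(=O)(=O)c2ccccc2)cc1` carries the same nitrile sulfone side chain as compound 1 with an extra methoxy on its core, but in this assay compound 3 is recorded as "not determined" (no result reported), so where it stands remains open. Compound 4 `COc1ccc2[nH]c(-c3ccccc3)c(/C=C(\C#N)S(=O)(=O)c3ccccc3)c2c1` arises from compound 3 by the change (hydrogen in place of methoxy on an aromatic carbon), which cut one bond further out reads 4-methoxyphenyl to phenyl. Among the measured compounds shown here, since compound 3 has no value, no measured step can be drawn, and any expectation for compound 4 must lean on the side chain it shares with compound 1, which gave 1100 nM. The loss of one methoxy is expected to move this assay little, if at all, beyond its scatter. Compound 4 is therefore estimated at 1500 nM in this assay, within a range of 500 nM to 5000 nM.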

Compound 4, concentration for 50% growth inhibition: 9300 nM
The estimate for compound 4 lay 6.2-fold (0.79 log units) below the measured number, outside the stated range (above it).
By their numbers in this assay, from the lowest: compound 1; then compounds 4 and 2 (each within the scatter of the next).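

Among the compounds shown here, compound 3 carries no single number in this assay, and no step from it to compound 4 can be read. The compounds shown leave open what the change from 4-methoxyphenyl to phenyl does in this assay. Nothing available bears on the result for compound 4.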